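This account rests on a few compounds, and the source may have more. Where it says the series, first, only, none or still open, it means among the compounds named here.

Compound 2, with structure `Oc1cccc2[nH]c(-c3ccc(-c4ccc(-c5ccc(F)cc5)cc4)cc3)nc12`, is the stronger of the two measured compounds: in a functional assay on A549 cells (Homo sapiens) for inhibition, read by sulforhodamine B assay (a higher number here means a weaker inhibitor of growth, a lower number a stronger inhibitor of growth), compound 2 gives 170 nM, whereas compound 1, with structure `Oc1ccc(-c2ccc(-c3ccc(-c4nc5ccccc5[nH]4)cc3)cc2)cc1`, gives 33100 nM in this assay, a gap well beyond the scatter of the measurement. Among the compounds with values here, the two differ in more than one place, so no single step connects them. Compound 3, with structure `Oc1ccc(-c2ccc(-c3ccc(-c4nc5c(O)cccc5[nH]4)cc3)cc2)cc1`, is reached from compound 2 by one change: hydroxy in place of fluoro on an aromatic carbon. Compound 1, the weaker of the measured pair, also carries a hydroxy rather than a fluoro at that position, though it lacks the hydroxy on the core that compound 2 has. The step from compound 2 to compound 3 is therefore expected to be modest and toward a higher number, roughly a 3.5-fold higher number from compound 2 to compound 3 (0.55 log units; beyond the scatter). Compound 3 is estimated to give 600 nM in this assay, with a likely range from 150 nM to 4000 nM.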

Compound 3, concentration for 50% growth inhibition: 170 nM
Beside the measured number, compound 3's estimate is 3.5-fold (0.55 log units) above it; low and high end bracket the measured number.
By their numbers in this assay, from the lowest: compounds 2 and 3 (each within the scatter of the next); then compound 1.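

In this assay, the change from 4-fluorophenyl to 4-hydroxyphenyl gives no change at the digits printed from compound 2 to compound 3 (within the scatter), so at this place, para to a large group, the two groups cannot be told apart in this read-out. The hydroxy on the core, by contrast, now stands out as a single change with the 4-hydroxyphenyl end held in place, giving a 190-fold lower number from compound 1 to compound 3 (2.29 log units; beyond the scatter), which the first pair, differing in more than one place, could not show. Nothing given here explains either step.

As far as these compounds go, it remains open whether the hydroxy on the core would count for as much with the 4-fluorophenyl end in place. Also open, from the compounds shown here alone, is whether an amine, a methoxy group or a carboxylic acid at the same place would leave the number unchanged, as the fluoro and hydroxy groups do.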